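Changing the Aryl Partner on the Shared Core of Compound 3

The source may hold more compounds than are shown below. What is called first, only, known or untested is meant among the compounds shown, and "the series" means these compounds.

Compound 1 `CC(=O)n1cc(/C=C(/C(=O)O)c2ccccc2)c2cc(OCc3ccccc3)ccc21` in a functional assay on KB cells (Homo sapiens) for cytotoxicity, read by MTT assay, with a stated time of 72 h (a higher number here means a weaker inhibitor, a lower number a stronger inhibitor), gives 55500 nM. Compound 2 `COc1ccccc1/C(=C\c1cn(C(C)=O)c2ccc(OCc3ccccc3)cc12)C(=O)O` reaches only a limit of the assay, > 100000 nM. Compound 3 `CC(=O)n1cc(/C=C(/C(=O)O)c2ccc(Cl)cc2)c2cc(OCc3ccccc3)ccc21` likewise stops at a limit, > 100000 nM. The methoxy brought an at least 1.8-fold higher number from compound 1 to compound 2 (0.25 log units; that floor lies within the scatter), and the chloro brought an at least 1.8-fold higher number from compound 1 to compound 3 (0.25 log units; that floor lies within the scatter). Between the two limits the step that the two limits leave unreadable from compound 2 to compound 3. Compound 4 `COc1ccc(/C(=C\c2cn(C(C)=O)c3ccc(OCc4ccccc4)cc23)C(=O)O)cc1OC` differs from compound 3 in one place: 3,4-dimethoxyphenyl in place of 4-chlorophenyl on a double-bonded chain carbon bound to a carbonyl carbon and a double-bonded chain carbon. Among the measured compounds shown here, no measured step puts a 3,4-dimethoxyphenyl at this place, and with the limit of > 100000 nM in this assay, at which 2 of the 3 values shown sit, the numbers offer no footing for a change in either direction. The step from compound 3 to compound 4 is therefore expected to be a step that the limit leaves unreadable from compound 3 to compound 4, none beyond the scatter. Compound 4 is estimated at 120000 nM, with a range from 50000 nM to 300000 nM.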

Compound 4, half-maximal inhibitory concentration: 96700 nM
Beside the measured number, compound 4's estimate is 1.2-fold (0.09 log units) above it, within the range that was stated.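

In this assay, the 3,4-dimethoxyphenyl gives this position a readable number, and the step from the plain phenyl is a 1.7-fold higher number from compound 1 to compound 4 (0.24 log units; within the scatter). Against the two partners that stopped at limits, only floors can be read: an at least 1.0-fold lower number from compound 2 to compound 4 (0.01 log units; that floor lies within the scatter) and an at least 1.0-fold lower number from compound 3 to compound 4 (0.01 log units; that floor lies within the scatter). So no aryl partner shown separates from another beyond the scatter, and the sizes of these steps stay uncertain for this reason: the limit of > 100000 nM in this assay, at which 2 of the 4 values shown sit.

Going by these compounds, whether an amine or a hydroxyl on this aryl partner would move the number beyond the scatter from that of compound 1 remains open. So does the effect of an ester in place of the carboxylic acid.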